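This account rests on a few compounds, and the source may have more. Where it says the series, first, only, none or still open, it means among the compounds named here.

Measured compounds:
Compound 1 `CC1(C)[C@H](c2c[nH]cn2)[C@H]1c1cccc2c1CCO2`: in a functional assay on AP1 cells for inhibition of sodium/hydrogen exchanger 1 (Homo sapiens) (on this read-out higher numbers stand for weaker inhibition and lower numbers for stronger inhibition), compound 1 gives > 30000 nM, which is a limit of the assay and not a number.
Compound 2 `CC1(C)[C@H](c2cc(Cl)cc(Cl)c2)[C@H]1c1c[nH]c(N)n1`: in this assay compound 2 gives 180 nM.
Compound 3 `CC1(C)[C@H](c2cccc(Cl)c2)[C@H]1c1c[nH]c(N)n1`: in this assay compound 3 gives 750 nM.

Among the measured compounds shown here, compound 1 stands at the limit of > 30000 nM in this assay, at which 1 of the 3 values shown sits; it offers only a limit, so no step from compound 1 to compound 2 or to compound 3 can be measured. For the measured compounds named here, the one measured step, a 4.2-fold higher number from compound 2 to compound 3 (0.62 log units; beyond the scatter), concerns a chloro group on an aromatic carbon elsewhere in the molecule and is modest in size. Compound 4 `Cc1[nH]cnc1[C@@H]1[C@@H](c2cccc3c2CCO3)C1(C)C` differs from compound 1 by methyl in place of hydrogen on an aromatic carbon. Going by the values given here, no measured pair touches that ring, so the measured step does not bear on this change. With compound 1 at the limit and nothing to suggest a gain, the step that the limit leaves unreadable from compound 1 to compound 4 is expected to be none beyond the scatter, with compound 4 most likely again reported only as a limit. Compound 4 is therefore estimated at 40000 nM, within 10000 nM to 150000 nM.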

Compound 4, half-maximal inhibitory concentration: 11000 nM
Compound 4: the middle estimate sits 3.6-fold (0.56 log units) above what was measured; measured number inside the range.
By their numbers in this assay, from the lowest: compound 2; then compound 3; then compound 4. At a limit, above all of these: compound 1.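

Among the compounds shown here, replacing 1H-imidazol-4-yl with 5-methyl-1H-imidazol-4-yl gives an at least 2.7-fold lower number from compound 1 to compound 4 (0.43 log units; beyond the scatter), so this ring position, which no earlier pair touched, does respond to change. A single methyl, only one added heavy atom, is enough to give a measurable result: in this assay compound 4 gives 11000 nM. The full size of this step remains unknown because compound 1 is reported only as a limit of the assay, not as a number: the limit of > 30000 nM in this assay, at which 1 of the 4 values shown sits.

As far as these compounds go, whether ethyl, chloro or an amine at this same place would match, exceed or lose the effect of methyl remains open. From the compounds shown here alone, it is also open whether adding methyl at this position would lower the number in the same way for compound 2 and compound 3, which carry chlorinated rings and an amino-substituted imidazole.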